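From hydroxy to acetamido on a saturated chain

The compounds below may be only part of what the source reports. "The series", "measured", "known", "first", "only" and "open" are said of these compounds alone.

Measured so far in a physicochemical assay for lipophilicity, read by HPLC; on this read-out higher numbers stand for higher lipophilicity and lower numbers for lower lipophilicity:
- compound 1 `Cc1ccsc1C(=CCCN(C)C(CCN)C(=O)NCc1ccccc1Cl)c1sccc1C` gives 6.11
- compound 2 `Cc1ccsc1C(=CCCN(C)C(CC(C)O)C(=O)NCc1ccccc1Cl)c1sccc1C` gives 5.95; 5.67 (2 entries)
- compound 3 `Cc1ccsc1C(=CCCN(C)C(CCO)C(=O)NCc1ccccc1Cl)c1sccc1C` gives 6.23

Compound 3 stands at 6.23 and lies within the scatter of compound 1. Compound 2 offers no single number to compare, only several entries (the several entries of compound 2 in this assay, 5.95; 5.67 (2 entries)). Compound 4 `CC(=O)NCCC(C(=O)NCc1ccccc1Cl)N(C)CCC=C(c1sccc1C)c1sccc1C` keeps the shared core and changes one group, as follows: acetamido in place of hydroxy on a saturated chain carbon, three bonds along the chain from an amine nitrogen and a carbonyl carbon. This puts acetamido in place of hydroxy on a saturated chain carbon. Among the compounds with values here, the only measured step at this place is a number 0.12 log units higher from compound 1 to compound 3 (within the scatter), and it exchanges a different pair of groups, so it is only a loose guide. On that guide, no step beyond the scatter is expected in this assay. The expected step is small (a number 0.08 log units lower from compound 3 to compound 4 (within the scatter)). For compound 4 the estimated value is 6.15 (expected range 5.75 to 6.55).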

Compound 4, partition coefficient: 6.46
For compound 4 the middle estimate is 0.31 log units below the measured one, within the range that was stated.
By their numbers in this assay, from the lowest: compounds 1, 3 and 4 (each within the scatter of the next, the first and the last beyond it).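

In this assay the step at this position is a number 0.23 log units higher from compound 3 to compound 4 (within the scatter) even though acetamido brings 4 heavy atoms where hydroxy has 1. Acetyl in place of hydrogen on an amine nitrogen gives a number 0.35 log units higher from compound 1 to compound 4 (beyond the scatter), the first step at this position to clear the scatter. Nothing shown gives a reason for either step.

On these data alone, whether a carboxylic acid at this position, or a propionyl group on this amine nitrogen, would fall near these numbers stays open. The compounds shown also cannot tell whether the acetyl step would hold on a longer chain.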